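The compounds below may be only part of what the source reports. "The series", "measured", "known", "first", "only" and "open" are said of these compounds alone.

Compound 3 `CC(C)(CC(=O)N[C@@H]1CCc2ccccc2N(Cc2ccc(-c3ccccc3-c3nn[nH]n3)cc2)C1=O)NC[C@H](O)CO` gives the lowest number of the three measured compounds in a functional assay (Pituitary gland cell) with Rattus norvegicus as the target (a lower number here means that less compound is needed, a higher number that more compound is needed for the effect), at 10 nM. Compound 1 `CCOC(=O)CNC(C)(C)CC(=O)N[C@@H]1CCc2ccccc2N(Cc2ccc(-c3ccccc3-c3nn[nH]n3)cc2)C1=O` carries an ethoxycarbonyl where compound 3 carries the 1,2-dihydroxyethyl; in this assay compound 1 gives 56 nM. Compound 2 `CC(C)[C@H](O)CNC(C)(C)CC(=O)N[C@@H]1CCc2ccccc2N(Cc2ccc(-c3ccccc3-c3nn[nH]n3)cc2)C1=O` carries a 1-hydroxy-2-methylpropyl at that place, and in this assay compound 2 gives 1000 nM. Compound 4 `CCCNC(C)(C)CC(=O)N[C@@H]1CCc2ccccc2N(Cc2ccc(-c3ccccc3-c3nn[nH]n3)cc2)C1=O` is the next compound in the series, and the change from compound 3 is ethyl in place of 1,2-dihydroxyethyl on a saturated chain carbon bound to an amine nitrogen.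

Going by the values given here, two measured steps bear on this change, both ending at compound 3: a 5.6-fold lower number from compound 1 to compound 3 (0.75 log units; beyond the scatter) and a 100-fold lower number from compound 2 to compound 3 (2.00 log units; beyond the scatter). Both show that the 1,2-dihydroxyethyl gives a lower number than either of the other groups tried at this place, and an 18-fold higher number from compound 1 to compound 2 (1.25 log units; beyond the scatter) shows that those other two groups also differ widely among themselves. Among the compounds with values here, compound 4 carries an ethyl, with no hydrogen-bond donors or acceptors, so no measured compound matches it closely; the direction is expected to be towards a higher number, and the size is uncertain. Compound 4 is therefore expected to give about 200 nM in this assay, with a range from 40 nM to 2000 nM. The expected step is a 20-fold higher number from compound 3 to compound 4 (1.30 log units; beyond the scatter).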

Compound 4, concentration for half-maximal effect: 50 nM
The estimate for compound 4 lay 4.0-fold (0.60 log units) above the measured number, within the range that was stated.
By their numbers in this assay, from the lowest: compound 3; then compounds 4 and 1 (each within the scatter of the next); then compound 2.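

In this assay the ethyl of compound 4, which brings no hydrogen-bond donors or acceptors, stands level with the ethoxycarbonyl (a 1.1-fold lower number from compound 1 to compound 4 (0.05 log units; within the scatter)), so a group of this kind at this place can match compound 1. Groups bearing a hydroxyl now fall on both sides of the ethyl: compound 3 keeps a lower number with its 1,2-dihydroxyethyl (a 5.0-fold higher number from compound 3 to compound 4 (0.70 log units; beyond the scatter)), while the 1-hydroxy-2-methylpropyl of compound 2 sits far higher (a 20-fold lower number from compound 2 to compound 4 (1.30 log units; beyond the scatter)), so across these compounds a hydroxyl on this chain does not by itself give a lower number. No measurement at hand accounts for these differences.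

From the compounds shown here alone, it stays open whether a carboxylic acid, a primary amine or a longer unbranched alkyl chain on this saturated chain carbon would fall nearer to compound 3 or to compound 4. Also open, going by these compounds, are the part played by the defined stereocentre of the 1,2-dihydroxyethyl and whether a single hydroxymethyl would be enough to reach the number of compound 3.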